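Permeability notes: compound 1 and the benzyl replacement in compound 3

This account rests on a few compounds, and the source may have more. Where it says the series, first, only, none or still open, it means among the compounds named here.

The series was profiled in an ADME assay for permeability, using PAMPA, with a stated time of 30 min, at pH 7.4; a higher number here means that the compound crosses the layer faster, a lower number that the compound crosses the layer more slowly. Among the compounds with values here, compound 1 `COc1ccc(Oc2ccc3c(NCCCNCc4cc(F)ccc4OC)ccnc3c2)cc1` gives 317 10^-6 cm/s in this assay, the highest of the two numbers measured so far. Within the data shown here, compound 2 `CC(C)Cc1ccc2c(NCCCNCc3ccco3)ccnc2c1` gives 23 10^-6 cm/s in this assay, a lower number, and the gap between the two values is beyond the scatter; the two structures differ in more than one place, so no single step can be drawn from compound 2 to compound 1.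

Compound 3 `COc1ccc(F)cc1CNCCCNc1ccnc2cc(Cc3cc(C)cc(C)c3)ccc12` has not yet been measured in this assay. It differs from compound 1 as follows: 3,5-dimethylbenzyl in place of 4-methoxyphenoxy on an aromatic carbon. The group leaving and the group entering have the same count of heavy atoms and each carries one six-membered aromatic ring of carbon only; the entering group carries no hydrogen-bond acceptors where the leaving one carried two.

Among the measured compounds shown here, with no measured step to lean on, no step beyond the scatter is expected here. For compound 3 the estimate in this assay is 260 10^-6 cm/s, with a range from 110 10^-6 cm/s to 550 10^-6 cm/s, which means an expected step of a 1.2-fold lower number from compound 1 to compound 3 (0.09 log units; within the scatter) from compound 1.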

Compound 3, apparent permeability: 23 10^-6 cm/s
Estimate against measurement, compound 3: 11-fold (1.05 log units) above; the whole stated range lies above it.
By their numbers in this assay, from the lowest: compounds 2 and 3 (each within the scatter of the next); then compound 1.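

In this assay, within the data shown here, this position on the shared core turns out not to be indifferent to what it carries: 3,5-dimethylbenzyl in place of 4-methoxyphenoxy gives a 14-fold lower number from compound 1 to compound 3 (1.14 log units; beyond the scatter) and is the first single-place step. The leaving and entering groups have the same count of heavy atoms and each carries one six-membered aromatic ring of carbon only, so a step of this size is possible here with both of those counts unchanged, while the hydrogen-bond acceptors of the leaving group are absent from the entering one. Nothing measured on these compounds accounts for the step, and this single pair gives no cause for it.

The pair changes the oxygen link, the methoxy and the two methyl groups all at once, so an unsubstituted phenoxy or a plain benzyl at this position would be needed to tell their shares apart. As far as these compounds go, whether the same replacement gives a step of similar size with a different side chain on the shared core also remains open.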